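The source may report more compounds than this note shows. Statements on the series, on what has been measured and on what is new or still open speak of the compounds shown alone.

Measured compounds in this series:

Compound 1, `O=C(Nc1cc(C(F)(F)F)cc(C(F)(F)F)c1)c1ccc(Cl)cc1O`: 200 nM
Compound 2, `Cc1ccc(C(=O)Nc2ccc(C#N)cc2)c(O)c1`: 2420 nM

Both values come from a functional assay on HL-60 cells (Homo sapiens) for cytotoxicity, read by luminescence and CellTiter-Glo, with a stated time of 3 days; on this read-out lower numbers stand for stronger inhibition and higher numbers for weaker inhibition. Among the two numbers compound 2 stands highest; compound 1 is its only neighbour, with a lower number, and the gap between them lies beyond the scatter. Since the two compounds differ in several places at once, nothing more is drawn from that pair than what the two values show.

The next compound to be measured is compound 3, `N#Cc1ccc(NC(=O)c2ccc(Br)cc2O)cc1`. Against compound 2 the change is a single one: bromo in place of methyl on an aromatic carbon. The group that leaves and the group that enters each count one heavy atom, and neither adds a donor or an acceptor.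

Within the data shown here, no step between measured compounds of this kind is available, so the size of the step in this assay is a matter of expectation only. A modest move toward a lower number is expected, though it may well remain within the scatter; the direction is uncertain without a matched pair. Compound 3 is therefore estimated at 1500 nM, with a range from 500 nM to 5000 nM, which corresponds to an expected step of a 1.6-fold lower number from compound 2 to compound 3 (0.21 log units; within the scatter).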

Compound 3, half-maximal inhibitory concentration: 1210 nM
Compound 3: the middle estimate sits 1.2-fold (0.09 log units) above what was measured; the measured number falls inside the stated range.
By their numbers in this assay, from the lowest: compound 1; then compounds 3 and 2 (each within the scatter of the next).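

In this assay the series gains its first reading at a single position: there is a 2.0-fold lower number from compound 2 to compound 3 (0.30 log units; within the scatter) for bromo in place of methyl on an aromatic carbon, meta to a hydroxy group and para to a large group. At this position, with the rest of the structure held constant, one heavy atom replaces another and neither group brings a hydrogen-bond donor or acceptor; the two compounds cannot be told apart in this assay, so this exchange has no effect that can be read beyond the scatter. No measurement of any other kind is available to explain this outcome.

From the compounds shown here alone, whether an amine, a carboxylic acid, a methoxy group or a longer chain such as propyl at this position would stay within the scatter remains open, since one exchange between two small groups sets no limit on what the position tolerates. Going by these compounds, compound 1 at 200 nM differs from compound 2 and compound 3 in several places, so which of its differences goes with its number also remains open.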